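A few compounds are considered here, and "the series" means these few. Any claim that something is new, unique, unknown or untested is made for them only; others in the source may bear on it.

Within the data shown here, compound 3 `NS(=O)(=O)c1cc(-c2nnc(CNC(=O)c3ccccc3)o2)c(Cl)cc1SCc1ccccc1` gives 42000 nM in a functional assay on HCT-116 cells (Homo sapiens) for cytotoxicity, read by MTT assay, with a stated time of 72 h (on this read-out lower numbers stand for stronger inhibition and higher numbers for weaker inhibition), the lowest of the three numbers measured so far. Compound 1 `NS(=O)(=O)c1cc(-c2nnc(CN3CCN(c4ccccc4)CC3)o2)c(Cl)cc1SCc1ccccc1` gives 105000 nM, and compound 2 `NC(=O)c1cn(Cc2nnc(-c3cc(S(N)(=O)=O)c(SCc4ccccc4)cc3Cl)o2)nn1` gives 72000 nM. The step of a 2.5-fold lower number from compound 1 to compound 3 (0.40 log units; beyond the scatter) is the only one beyond the scatter; the steps of a 1.7-fold lower number from compound 2 to compound 3 (0.23 log units; within the scatter) and a 1.5-fold lower number from compound 1 to compound 2 (0.16 log units; within the scatter) are not. Compound 4 `NS(=O)(=O)c1cc(-c2nnc(/C=C/c3ccc(Cl)cc3)o2)c(Cl)cc1SCc1ccccc1` carries 2-(4-chlorophenyl)ethenyl in place of benzamidomethyl on an aromatic carbon. All three measured steps vary a group on a saturated chain carbon, whereas compound 4 removes that chain carbon together with the benzamido group, so none of them bears directly on this change; together they only show that variation at that site has shifted the number modestly. The account therefore expects no step beyond the scatter, a 1.2-fold higher number from compound 3 to compound 4 (0.08 log units; within the scatter), and estimates compound 4 at 50000 nM, between 18000 nM and 140000 nM.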

Compound 4, half-maximal inhibitory concentration: 12000 nM
Compound 4: the middle estimate sits 4.2-fold (0.62 log units) above what was measured; the measured number lies below the stated range.
By their numbers in this assay, from the lowest: compound 4; then compounds 3, 2 and 1 (each within the scatter of the next, the first and the last beyond it).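

Placing 2-(4-chlorophenyl)ethenyl directly on this aromatic carbon gives a 3.5-fold lower number from compound 3 to compound 4 (0.54 log units; beyond the scatter) in this assay, and a 6.0-fold lower number from compound 2 to compound 4 (0.78 log units; beyond the scatter) against the triazole-bearing group, so the saturated chain carbon and its amide or triazole group are not required for the lower number. The entering group carries no hydrogen-bond donor or acceptor, yet compound 4 has the lowest number of the series. Nothing measured here gives a reason for this drop.

Compound 4 changes the link and the aryl group together, so their shares remain unseparated. A 2-phenylethenyl group, lacking the chlorine, or a 2-(4-chlorophenyl)ethyl group, with a saturated link, would tell them apart.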